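This account rests on a few compounds, and the source may have more. Where it says the series, first, only, none or still open, it means among the compounds named here.

Measured so far in an ADME assay on MT4 cells (Homo sapiens) for cytotoxicity, read by MTT assay; on this read-out higher numbers stand for lower toxicity in this test and lower numbers for higher toxicity in this test:

- compound 1 `O=C(CSc1nncnc1-c1ccccc1Cl)Nc1ccccn1`: 172000 nM
- compound 2 `Cc1ccc2sc(NC(=O)CSc3nncnc3-c3ccccc3Cl)nc2c1`: 137000 nM
- compound 3 `O=C(CSc1nncnc1-c1cccc2ccccc12)Nc1ccccc1F`: 65000 nM

Compound 1 gives the highest of the three numbers in this assay. Compound 2 sits within the scatter of it, so the two read alike. Compound 3 lies beyond the scatter on the low side, so compound 1 shows the lower toxicity of that pair.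

The next compound, compound 4 `O=C(CSc1nncnc1-c1ccccc1Cl)Nc1ccccc1F`, is compound 1 with a change on the amide-type nitrogen: 2-fluorophenyl in place of pyridin-2-yl on an amide-type nitrogen. Compound 4 thereby carries the same amide substituent as compound 3, but keeps the core of compound 1 rather than that of compound 3. Compound 3 differs from compound 1 both in its amide substituent and in its core. Among the measured compounds shown here, no pair differing in only one place has been measured, so the two differences cannot be separated on the present three compounds.

The step from compound 1 to compound 4 is therefore expected to be small, leaning toward a lower number, with a 1.4-fold lower number from compound 1 to compound 4 (0.16 log units; within the scatter) as the estimate. For compound 4 the value expected in this assay is 120000 nM, with a range from 50000 nM to 260000 nM.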

Compound 4, half-maximal cytotoxic concentration: 98000 nM
Estimate against measurement, compound 4: 1.2-fold (0.09 log units) above; measured number inside the range.
By their numbers in this assay, from the lowest: compounds 3, 4, 2 and 1 (each within the scatter of the next, the first and the last beyond it).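

On the amide-type nitrogen, 2-fluorophenyl in place of pyridin-2-yl gives a 1.8-fold lower number from compound 1 to compound 4 (0.24 log units; within the scatter) in this assay on the core of compound 1, so this exchange does not separate the two compounds. Compound 3 at 65000 nM and compound 4 at 98000 nM carry the same amide substituent and differ in the core, and these values lie within the scatter of each other, so neither single difference on its own stands beyond the scatter here. Nothing at hand explains these readings.

Open, on these data alone, is how a group of another kind on this nitrogen, such as a carboxylic acid or a longer alkyl chain bearing an amine, would read in this assay. Also open, as far as these compounds go, is whether the exchange of pyridin-2-yl for 2-fluorophenyl reads the same on other cores.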